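Methyl to methoxy on the aryl group of compound 2

This account rests on a few compounds, and the source may have more. Where it says the series, first, only, none or still open, it means among the compounds named here.

Two compounds of this series have numbers in a functional assay on A549 cells (Homo sapiens) for cytotoxicity, read by MTT assay; a higher number here means a weaker inhibitor, a lower number a stronger inhibitor. Compound 1, `COC(=O)C[C@@H]1C[C@@H](O)[C@H](C)[C@H](c2ccccc2)N1`, gives 8500 nM in this assay. Compound 2, `COC(=O)C[C@H]1C[C@H](O)[C@@H](C)[C@@H](c2ccc(C)cc2)N1`, gives 97600 nM in this assay. Compound 2 therefore stands at the higher of the two numbers: the gap from compound 1 to compound 2 is beyond the scatter, and compound 2 is the weaker of the pair. The two compounds differ in more than one place, so what they show is only the two values side by side.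

Compound 3, `COC(=O)C[C@H]1C[C@H](O)[C@@H](C)[C@@H](c2ccc(OC)cc2)N1`, is not yet measured. It comes from compound 2 by a single change, (methoxy in place of methyl on an aromatic carbon).

Among the measured compounds shown here, no step of this kind between measured compounds is available, so the size of the effect is open. The expectation is a step of small size, if any, in this assay, more likely toward a lower number than a higher one, but plausibly within the scatter. The number expected for compound 3 in this assay is 70000 nM, with a range from 20000 nM to 250000 nM, which means an expected step of a 1.4-fold lower number from compound 2 to compound 3 (0.14 log units; within the scatter).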

Compound 3, half-maximal inhibitory concentration: 5400 nM
Compound 3: the middle estimate sits 13-fold (1.11 log units) above what was measured; the measured number lies below the stated range.
By their numbers in this assay, from the lowest: compounds 3 and 1 (each within the scatter of the next); then compound 2.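

In this assay, the aromatic carbon para to a large group proves to be a sensitive place: methoxy in place of methyl gives an 18-fold lower number from compound 2 to compound 3 (1.26 log units; beyond the scatter), a large step for a change this small in heavy atoms. Among the compounds shown here, this is the first comparison that isolates one change, since compounds 1 and 2 differ in more than one place and could show only two values side by side; it establishes that the group at this position alone can move the number well beyond the scatter. No measurement available here bears on the origin of this step.

The compounds shown leave open whether the oxygen of the methoxy group or simply the longer group carries the step, a question that ethyl, with carbon in place of that oxygen, and hydroxyl, which keeps the oxygen without the methyl, would help to separate at the same carbon. Also open, going by these compounds, is whether methoxy gives a step of similar size and direction when placed on the unsubstituted phenyl group of compound 1.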